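Nitro and formyl substitution on a chlorobenzyl-bearing fused core

This account rests on a few compounds, and the source may have more. Where it says the series, first, only, none or still open, it means among the compounds named here.

Compound 1 `Clc1ccc(Cc2nn3cc(-c4ccccc4)nc3s2)cc1` serves as the parent. In a functional assay on L1210 cells (Mus musculus) for cytotoxicity, with a stated time of 48 h (on this read-out lower numbers stand for stronger inhibition and higher numbers for weaker inhibition), compound 1 reaches only a limit, > 250000 nM, which is the limit of > 250000 nM in this assay, at which 1 of the 3 values shown sits, rather than a number. Compound 2 `O=[N+]([O-])c1ccc(-c2cn3nc(Cc4ccc(Cl)cc4)sc3n2)cc1` carries nitro in place of hydrogen on an aromatic carbon. In this assay compound 2 gives 214000 nM; the step is an at least 1.1-fold lower number from compound 1 to compound 2 (0.06 log units; that floor lies within the scatter). Compound 3 `O=Cc1c(-c2ccccc2)nc2sc(Cc3ccc(Cl)cc3)nn12` carries formyl in place of hydrogen on an aromatic carbon. In this assay compound 3 gives 20000 nM, the step being an at least 12-fold lower number from compound 1 to compound 3 (1.09 log units; beyond the scatter), and compound 3 stands lowest of the two numbers.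

Compound 4 `O=Cc1c(-c2ccc([N+](=O)[O-])cc2)nc2sc(Cc3ccc(Cl)cc3)nn12` is not yet measured; it differs from compound 3 by nitro in place of hydrogen on an aromatic carbon, the same change as between compound 1 and compound 2, at a place described in the same words, while the two cores differ by the formyl already described. Since that earlier step was an at least 1.1-fold lower number from compound 1 to compound 2 (0.06 log units; that floor lies within the scatter), the step from compound 3 to compound 4 is expected to be small, a 1.3-fold lower number from compound 3 to compound 4 (0.10 log units; within the scatter). Compound 4 is thus estimated at 16000 nM, expected between 5000 nM and 60000 nM.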

Compound 4, half-maximal inhibitory concentration: 15000 nM
Compound 4: the middle estimate sits 1.1-fold (0.03 log units) above what was measured; the measured number falls inside the stated range.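

In this assay, nitro in place of hydrogen on the formyl-bearing core gives a 1.3-fold lower number from compound 3 to compound 4 (0.12 log units; within the scatter), while formyl in place of hydrogen on the nitro-bearing core gives a 14-fold lower number from compound 2 to compound 4 (1.15 log units; beyond the scatter). The nitro change therefore stays within the scatter on the formyl-bearing core, but its size on the core of compound 1 is known only as a floor, so no equal size on the two cores is shown: the same change on two cores in this assay, an at least 1.1-fold lower number (0.06 log units; that floor lies within the scatter) from compound 1 to compound 2 and a 1.3-fold lower number (0.12 log units; within the scatter) from compound 3 to compound 4; the limit leaves it open whether they differ. The formyl change lies beyond the scatter in both pairs and points the same way, although equal size is again not shown: the same change on two cores in this assay, an at least 12-fold lower number (1.09 log units; beyond the scatter) from compound 1 to compound 3 and a 14-fold lower number (1.15 log units; beyond the scatter) from compound 2 to compound 4; the limit leaves it open whether they differ.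

As far as these compounds go, it remains open whether a carboxylic acid or an amine in place of formyl would keep the lower number. From the compounds shown here alone, the effect of a longer chain in place of the chlorobenzyl group also remains open.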